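The source may report more compounds than this note shows. Statements on the series, on what has been measured and on what is new or still open speak of the compounds shown alone.

Within the data shown here, compound 2 `COc1cc(NC(C)CCCNC(=O)Nc2cccc(O)c2)c2ncccc2c1` is the only compound with an outright number in a functional assay on NCI-H460 cells (Homo sapiens) for inhibition, read by MTT assay, with a stated time of 72 h (a lower number here means a stronger inhibitor, a higher number a weaker inhibitor), where compound 2 gives 25000 nM. Compound 1 `COc1cc(NC(C)CCCNC(=O)NNC(=O)Nc2ccc(F)cc2)c2ncccc2c1` reaches only the limit of this assay, > 100000 nM. Among the measured compounds shown here, the single measured step, an at least 4.0-fold lower number from compound 1 to compound 2 (0.60 log units; beyond the scatter), concerns a different exchange and rests on that limit (the limit of > 100000 nM in this assay, at which 1 of the 2 values shown sits), so it bears only loosely on what follows. Compound 3 `COc1cc(NC(C)CCCNC(=O)Nc2ccc(Cl)cc2)c2ncccc2c1` differs from compound 2 by 4-chlorophenyl in place of 3-hydroxyphenyl on an amide-type nitrogen. For the measured compounds named here, no measured step covers this exchange, so for compound 3 he expects no shift beyond the scatter, an estimated step of a 1.2-fold higher number from compound 2 to compound 3 (0.08 log units; within the scatter). Compound 3 is therefore estimated at 30000 nM, between 8000 nM and 100000 nM.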

Compound 3, half-maximal inhibitory concentration: 34000 nM
Compound 3: middle estimate off by 1.1-fold (0.05 log units), on the low side; the measured number falls inside the stated range.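

In this assay, 4-chlorophenyl in place of 3-hydroxyphenyl on the amide-type nitrogen gives a 1.4-fold higher number from compound 2 to compound 3 (0.13 log units; within the scatter), so this exchange, which removes the hydrogen-bond donor and acceptor counted on the leaving group, separates compound 2 and compound 3 by no more than the scatter. The other new step, an at least 2.9-fold lower number from compound 1 to compound 3 (0.46 log units; beyond the scatter), rests on a limit and not on a number: the limit of > 100000 nM in this assay, at which 1 of the 3 values shown sits. The compounds shown leave open whether an amine or a carboxylic acid on this phenyl ring would move the number beyond the scatter. They also leave open what a longer chain would do.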